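The compounds below may be only part of what the source reports. "The series", "measured", "known", "first", "only" and "open" are said of these compounds alone.

Compound 1 `CC(C)C(Sc1nc2c(cnn2C)c(=O)n1-c1ccccc1)c1ccccc1`, 380 nM
Compound 2 `CC(Sc1nc2nn(CC3COC3)cc2c(=O)n1-c1ccccc1)c1ccccc1`, 100 nM

In an assay on isolated protein for inhibition of aldehyde dehydrogenase 1A1 (Homo sapiens) (a higher number here means a weaker inhibitor, a lower number a stronger inhibitor), compound 2 gives 100 nM, the lower of the two numbers measured; compound 1 gives 380 nM, which lies beyond the scatter above it. Compound 3 `CC(Sc1nc2nn(C3(C)COC3)cc2c(=O)n1-c1ccccc1)c1ccccc1` is not yet measured. It differs from compound 2 by 3-methyloxetan-3-yl in place of (oxetan-3-yl)methyl on an aromatic nitrogen. For the measured compounds named here, no measured pair here shows a comparable change, so the size of the step is an open guess; a step of modest size in either direction, possibly none beyond the scatter, is expected. For compound 3 a value of 180 nM is estimated, between 60 nM and 600 nM, which means an expected step of a 1.8-fold higher number from compound 2 to compound 3 (0.26 log units; within the scatter).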

Compound 3, half-maximal inhibitory concentration in the aldehyde dehydrogenase 1A1 assay: 93 nM
The estimate for compound 3 lay 1.9-fold (0.29 log units) above the measured number; low and high end bracket the measured number.
By their numbers in the aldehyde dehydrogenase 1A1 assay, from the lowest: compounds 3 and 2 (each within the scatter of the next); then compound 1.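

In the aldehyde dehydrogenase 1A1 assay, 3-methyloxetan-3-yl in place of (oxetan-3-yl)methyl on this aromatic nitrogen gives a 1.1-fold lower number from compound 2 to compound 3 (0.03 log units; within the scatter), so at this position the same atoms, joined differently, leave inhibition unchanged within the scatter. The change does register in a physicochemical assay for solubility, using the shake flask method, in phosphate buffer, with a stated time of 24 h, at pH 7.4 (a lower number here means a less soluble compound, a higher number a more soluble compound), where compound 2 gives 77000 nM and compound 3 gives 19000 nM, and solubility falls: the measured solubility of compound 2, 77000 nM, and of compound 3, 19000 nM, a 4.1-fold lower number (0.61 log units; beyond the scatter)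

The compounds shown leave open whether an amine or a carboxylic acid on this nitrogen would keep the inhibition, and what either would do to solubility. Compound 1 differs from compound 2 in more than one place, so it cannot settle this.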